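The source may hold more compounds than are shown below. What is called first, only, known or untested is meant among the compounds shown, and "the series" means these compounds.

Measured compounds in an ADME assay on Vero cells (Chlorocebus sabaeus) for cytotoxicity, read by MTT assay, with a stated time of 72 h; a higher number here means that more compound is tolerated, a lower number that less compound is tolerated:
compound 1 `COC(=O)c1cc(-c2cccc(NC(=O)c3ccc(C4OC4C(=O)c4ccc(Cl)cc4)cc3)c2)on1` gives > 20 ug/mL, a limit of the assay.
compound 2 `CCOC(=O)c1nnn(-c2cccc(NC(=O)c3ccc(/C=C/C(=O)c4ccc(Cl)cc4)cc3)c2)c1C` gives "not determined" (no result reported).
compound 3 `COC(=O)c1cc(-c2cccc(NC(=O)c3ccc(/C=C/C(=O)c4ccc(F)cc4)cc3)c2)on1` gives > 20 ug/mL, a limit of the assay.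

Compound 1 stands at a limit of this assay rather than at a number. Of the three entries shown, only one other carries a limit and the third carries no single number at all, so compound 1 cannot be placed in order against either of them. Among the compounds with values here, the one measured step that differs in a single place, a step that the two limits leave unreadable from compound 1 to compound 3, is therefore unreadable, both ends sitting at the same limit. The evidence behind that comes down to the limit of > 20 ug/mL in this assay, at which 2 of the 3 values shown sit.

Compound 4 `COC(=O)c1cc(-c2cccc(NC(=O)c3ccc(/C=C/C(=O)c4cccc(F)c4)cc3)c2)on1` differs from compound 1 in one place: 2-((3-fluorophenyl)carbonyl)ethenyl in place of 3-((4-chlorophenyl)carbonyl)oxiran-2-yl on an aromatic carbon.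

Within the data shown here, only the step from compound 1 to compound 3 bears on this change, since it also swaps the oxiranyl group for an ethenyl group with a fluorophenyl carbonyl, and it gave no readable size. Among the measured compounds shown here, no step within or beyond the scatter can therefore be expected with any confidence. Compound 4 is estimated to sit at 20 ug/mL, with a range from 10 ug/mL to 40 ug/mL. The step this estimate means, a number no higher from compound 1 to compound 4 (the limit leaves the size open), is expected to be none beyond the scatter.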

Compound 4, half-maximal cytotoxic concentration: > 40 ug/mL
Compound 4: only a limit was reported (the forecaster's own chance of this, stated with the estimate: 70%); middle value at least 2.0-fold (0.30 log units) away from the limit.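

In this assay compound 4 gives > 40 ug/mL, a limit of the assay and not a number. Compound 1 and compound 3 also stand at limits, and the steps from each of them to compound 4 cannot be read. The compounds shown leave open where the half-maximal cytotoxic concentration of any of the three lies, and whether 3-fluorophenyl in place of 4-fluorophenyl changes it at all.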